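The source may report more compounds than this note shows. Statements on the series, on what has been measured and on what is new or still open speak of the compounds shown alone.

Measured so far in a functional assay on A549 cells (Homo sapiens) for antiproliferative activity, read by sulforhodamine B assay, with a stated time of 48 h; on this read-out higher numbers stand for weaker inhibition and lower numbers for stronger inhibition:
Compound 1 `COc1cc(OC)c2sc(-c3ccc(N/C=C\C(=O)c4ccc(OC)c(O)c4)c(C)c3)nc2c1`: 14300 nM
Compound 2 `COc1cc(OC)c2sc(-c3ccc(N/C=C\C(=O)c4ccc(OC)c([N+](=O)[O-])c4)c(C)c3)nc2c1`: 12100 nM
Compound 3 `COc1cc(OC)c2sc(-c3ccc(N/C=C\C(=O)c4cc(OC)c(OC)c([N+](=O)[O-])c4)c(C)c3)nc2c1`: 15400 nM

Compound 3, at 15400 nM, lies within the scatter of both compound 1 and compound 2, so these three values cannot be told apart in this assay. Compound 4 `COc1cc(OC)c2sc(-c3ccc(N/C=C\C(=O)c4cc(OC)c(OC)c(OC)c4)c(C)c3)nc2c1` departs from compound 3 in one place, with methoxy in place of nitro on an aromatic carbon. The site is ortho to a methoxy group and meta to a large group.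

Going by the values given here, no measured step makes this exact exchange, but two bear on it. Nitro in place of hydroxy gave a 1.2-fold lower number from compound 1 to compound 2 (0.07 log units; within the scatter), and methoxy in place of hydrogen gave a 1.3-fold higher number from compound 2 to compound 3 (0.10 log units; within the scatter). Both involve a group of the kind at issue here, and neither moved the number beyond the scatter. On this evidence, no step beyond the scatter is expected in this assay, and no direction can be claimed with confidence. The estimated step is a 1.2-fold lower number from compound 3 to compound 4 (0.07 log units; within the scatter). With so few compounds behind it, this expectation stays loose. For compound 4 the estimated value is 13000 nM, with an expected range from 5000 nM to 25000 nM.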

Compound 4, half-maximal inhibitory concentration: 14400 nM
Compound 4: the middle estimate sits 1.1-fold (0.04 log units) below what was measured, and the stated range covers the measured number.
By their numbers in this assay, from the lowest: compounds 2, 1, 4 and 3 (each within the scatter of the next).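

In this assay, going by these compounds alone, the direct exchange of nitro for methoxy at this site, ortho to a methoxy group and meta to a large group, is a step of a 1.1-fold lower number from compound 3 to compound 4 (0.03 log units; within the scatter) and so adds a first reading of this exact change, which no earlier step had given. The wider exchanges on the carbonyl carbon stay just as close: 3,4,5-trimethoxyphenyl in place of 4-methoxy-3-nitrophenyl is a step of a 1.2-fold higher number from compound 2 to compound 4 (0.08 log units; within the scatter) and 3,4,5-trimethoxyphenyl in place of 3-hydroxy-4-methoxyphenyl is a step of a 1.0-fold higher number from compound 1 to compound 4 (0.00 log units; within the scatter) in the same assay, so the four compounds cannot be told apart, whether this site carries hydroxy, nitro or methoxy. Nothing measured here accounts for how closely these values sit together.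

Going by these compounds, it remains open whether an amine, a carboxylic acid or a longer chain such as butoxy at this site would leave the number in this assay where it stands. Also open, on these data alone, is whether a change away from this ring, such as a fluorine or an ethyl in place of the methyl on the other aromatic ring of the shared core, would move it beyond the scatter.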